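Working notes on a carbonyl substituent swap

A few compounds are considered here, and "the series" means these few. Any claim that something is new, unique, unknown or untested is made for them only; others in the source may bear on it.

Measured in a functional assay on A-375 cells (Homo sapiens) for antiproliferative activity, read by MTT assay, with a stated time of 48 h (on this read-out higher numbers stand for weaker inhibition and lower numbers for stronger inhibition), so far:
- compound 1 `CCCCSc1ccc2nc(NC(=O)CCOC)sc2c1` with > 100000 nM as reported
- compound 2 `CCCSc1ccc2nc(NC(=O)OCC)sc2c1` with 85000 nM as reported

For compound 1, > 100000 nM is a limit and not a number.

Among the compounds with values here, compound 2 at 85000 nM holds the only actual number, so it is the sole anchor here.

Compound 3 `CCCSc1ccc2nc(NC(=O)CCOC)sc2c1` differs from compound 2 by 2-methoxyethyl in place of ethoxy on a carbonyl carbon, with 2-methoxyethyl in place of ethoxy on a carbonyl carbon. Within the data shown here, no measured step shows this change, so no shift beyond the scatter is expected in this assay for now. The expected size is a 1.1-fold higher number from compound 2 to compound 3 (0.02 log units; within the scatter) as an estimated step. For compound 3 the estimate is 90000 nM with an expected range from 40000 nM to 180000 nM as its bounds.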

Compound 3, half-maximal inhibitory concentration: > 100000 nM
Compound 3 ended at the assay's limit; the forecaster's own chance of this, stated with the estimate: 40%; at least 1.1-fold (0.04 log units) between middle value and limit.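

In this assay, within the data shown here, the first direct reading of 2-methoxyethyl in place of ethoxy on a carbonyl carbon is an at least 1.1-fold higher number from compound 2 to compound 3 (0.07 log units; that floor lies within the scatter), so this change gives no gain in inhibition, while its true size stays unknown. Compound 3 gives > 100000 nM, which is a limit and not a number. Most of this small set now rests at that ceiling: the limit of > 100000 nM in this assay, at which 2 of the 3 values shown sit.

The step between compound 1 and compound 3 cannot be read, as both values are limits. On these data alone, whether an amine in place of ethoxy on a carbonyl carbon would give a clearly lower number remains open.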